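Changing One Aromatic Group in a Kinase Inhibitor Series

The source may report more compounds than this note shows. Statements on the series, on what has been measured and on what is new or still open speak of the compounds shown alone.

Compound 1, `O=C(Nc1ccc(Br)cc1)Nc1ccc(Nc2ncnc3c2OCCN3)cc1`: > 10000 nM
Compound 2, `O=C(Nc1ccc(Nc2ncnc3c2OCCN3)cc1)Nc1ccc(C(F)(F)F)cc1`: 2470 nM

Both compounds share a common core and differ only in the group sitting on one six-membered aromatic ring of carbon only. Among the compounds with values here, in an assay on isolated protein for inhibition of proto-oncogene tyrosine-protein kinase receptor Ret variant V804L (Homo sapiens), read by 33P incorporation, with stated times of 15 min and 40 min (on this read-out lower numbers stand for stronger inhibition and higher numbers for weaker inhibition), compound 2 gives 2470 nM, the only plain number among the two results. Compound 1 reaches only (the limit of > 10000 nM in this assay, at which 1 of the 2 values shown sits), which is a limit of the assay rather than a measured number. Within the data shown here, the single measured step, an at least 4.0-fold lower number from compound 1 to compound 2 (0.60 log units; beyond the scatter), is therefore known only as a lower bound.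

Compound 3, `COc1ccc(NC(=O)Nc2ccc(Nc3ncnc4c3OCCN4)cc2)cc1`, is the next member: methoxy in place of trifluoromethyl on an aromatic carbon. Among the measured compounds shown here, no measured step exchanges trifluoromethyl for methoxy, so the step from compound 1 to compound 2 is only a loose guide: it shows that the group at this place can shift the result beyond the scatter, without saying which way methoxy will go. Compound 3 is therefore expected to land near 5000 nM, most likely between 1500 nM and 20000 nM. The expected step, a 2.0-fold higher number from compound 2 to compound 3 (0.31 log units; beyond the scatter), leans toward weaker inhibition, with wide uncertainty either way.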

Compound 3, half-maximal inhibitory concentration: 1220 nM
Estimate against measurement, compound 3: 4.1-fold (0.61 log units) above, outside the stated range (below it).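

In this assay, methoxy in place of trifluoromethyl gives a 2.0-fold lower number from compound 2 to compound 3 (0.31 log units; beyond the scatter). Within the data shown here, this is the first step at this position measured with a plain number at both ends, so it shows that the position still responds to a change between two groups that both give a reading, which the earlier pair could not show. Methoxy in place of bromo gives an at least 8.1-fold lower number from compound 1 to compound 3 (0.91 log units; beyond the scatter), which places both methoxy and trifluoromethyl on the stronger side of bromo, but this step is only a lower bound, as compound 1 holds a limit and not a measured number: the limit of > 10000 nM in this assay, at which 1 of the 3 values shown sits.

Methoxy differs from trifluoromethyl in several ways at once, being smaller and carrying a hydrogen-bond acceptor, and three compounds cannot show which of these differences, if any, accounts for the step. Going by these compounds, how an amine, a carboxylic acid or a longer chain such as ethoxy would read at this same place on the ring stays open, as does whether any group there could bring the numbers far lower than those of compound 2 and compound 3.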